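The compounds below may be only part of what the source reports. "The series", "measured", "known", "first", "only" and "open" are said of these compounds alone.

Compound 1 `CC(C)S(=O)(=O)N1CCC(CN(C2Cc3cc(C#N)ccc3N(Cc3cncn3C)C2)S(=O)(=O)c2ccccn2)CC1` gives 0.1 10^-6 cm/s in an ADME assay on Caco-2 cells (Homo sapiens) for permeability, in the apical to basolateral direction (a lower number here means that the compound crosses the layer more slowly, a higher number that the compound crosses the layer faster), and stands level with compound 3 `Cn1cnc(S(=O)(=O)N2CCC(CN(C3Cc4cc(C#N)ccc4N(Cc4cncn4C)C3)S(=O)(=O)c3ccccn3)CC2)c1`, which gives 0.1 10^-6 cm/s; together they hold the lowest numbers of the three measured. Among the compounds with values here, compound 2 `C=C(C)C(=O)N1CCC(CN(C2Cc3cc(C#N)ccc3N(Cc3cncn3C)C2)S(=O)(=O)c2ccccn2)CC1` gives 0.5 10^-6 cm/s, and a 5.0-fold higher number from compound 1 to compound 2 (0.70 log units; beyond the scatter) is the only step beyond the scatter, while no change at the digits printed from compound 1 to compound 3 (within the scatter) shows nothing. Compound 4 `Cn1cncc1CN1CC(N(CC2CCN(C(=O)OCc3ccccc3)CC2)S(=O)(=O)c2ccccn2)Cc2cc(C#N)ccc21` differs from compound 1 by benzyloxycarbonyl in place of isopropylsulfonyl on an amine nitrogen in a ring. The step of a 5.0-fold higher number from compound 1 to compound 2 (0.70 log units; beyond the scatter) bears on this: there too the isopropylsulfonyl on the amine nitrogen in the ring gave way to a carbonyl-bearing group, whereas compound 3 kept a sulfonyl. A modest rise in this assay is therefore expected, a 5.0-fold higher number from compound 1 to compound 4 (0.70 log units; beyond the scatter). Compound 4 is estimated at 0.5 10^-6 cm/s, within 0.15 10^-6 cm/s to 1.5 10^-6 cm/s.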

Compound 4, apparent permeability: 1 10^-6 cm/s
Compound 4: the middle estimate sits 2.0-fold (0.30 log units) below what was measured, and the stated range covers the measured number.
By their numbers in this assay, from the lowest: compounds 1 and 3 (each within the scatter of the next); then compounds 2 and 4 (each within the scatter of the next).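

On the amine nitrogen in the ring, benzyloxycarbonyl again puts a carbonyl-bearing group above the sulfonyl groups in this assay with a 10-fold higher number from compound 1 to compound 4 (1.00 log units; beyond the scatter) and a 10-fold higher number from compound 3 to compound 4 (1.00 log units; beyond the scatter) as the two steps. Among the carbonyl-bearing groups, a 2.0-fold higher number from compound 2 to compound 4 (0.30 log units; within the scatter) leaves benzyloxy and 1-methylethenyl on the carbonyl carbon unresolved, even though benzyloxycarbonyl brings a six-membered aromatic ring of carbon only. No measured evidence accounts for the gap between the sulfonyl and carbonyl-bearing groups.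

Still open, from the compounds shown here alone, is how a plain acetyl group or a urea bearing a dimethylamino group would read on this nitrogen. Also open, going by these compounds, is whether the same gap holds when the pyridine-bearing sulfonyl group elsewhere on the shared core is changed.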